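Changing the Amide Substituent and Paw Edema Inhibition

The source may hold more compounds than are shown below. What is called first, only, known or untested is meant among the compounds shown, and "the series" means these compounds.

Compound 1 `COc1ccc(-n2nc(C(=O)Nc3ccccc3OC)nc2-c2cc(OC)c(OC)c(OC)c2)cc1`: 44%
Compound 2 `COc1ccc(-n2nc(C(=O)Nc3ccccc3C)nc2-c2cc(OC)c(OC)c(OC)c2)cc1`: 74%
Compound 3 `COc1ccc(-n2nc(C(=O)Nc3ccc(C(=O)O)cc3)nc2-c2cc(OC)c(OC)c(OC)c2)cc1`: 109%

These three compounds were tested in a functional assay on the whole organism for inhibition, with Rattus norvegicus as the target, read by paw edema, with stated times of 30 min and 3 h, at a dose of 0.28 mmol/kg by the oral route; a lower number here means less inhibition, a higher number more inhibition at the dose given (going by the name of the read-out). Compound 1 stands lowest of the three: the nearest is a number 30 percentage points higher from compound 1 to compound 2 (beyond the scatter), and the furthest is a number 65 percentage points higher from compound 1 to compound 3 (beyond the scatter). Compound 4 `COc1ccc(-n2nc(C(=O)Nc3ccc(O)cc3)nc2-c2cc(OC)c(OC)c(OC)c2)cc1` differs from compound 1 in one place: 4-hydroxyphenyl in place of 2-methoxyphenyl on an amide-type nitrogen. Within the data shown here, two measured steps bear on this. The exchange of the whole group on the amide-type nitrogen, a number 65 percentage points higher from compound 1 to compound 3 (beyond the scatter), was large, while the smaller exchange of methyl for methoxy, a number 30 percentage points higher from compound 1 to compound 2 (beyond the scatter), was modest. Both run upward. The exact change to 4-hydroxyphenyl has not been measured, so a step upward beyond the scatter, but smaller than that to 4-carboxyphenyl, is expected. Compound 4 is estimated at 75%, within 50% to 100%, an expected a number 31 percentage points higher from compound 1 to compound 4 (beyond the scatter).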

Compound 4, a percentage reported as inhibition, in the whole organism at one dose (the size of the read-out at that dose, not a potency): 74%
The estimate for compound 4 lay 1 percentage points above the measured number; the range from low to high includes it.
By their numbers in this assay, from the lowest: compound 1; then compounds 2 and 4 (each within the scatter of the next); then compound 3.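

Replacing 2-methoxyphenyl with 4-hydroxyphenyl on the amide-type nitrogen gives a number 30 percentage points higher from compound 1 to compound 4 (beyond the scatter), so a carboxy group is not needed for a rise at this position, and 2-methylphenyl and 4-hydroxyphenyl show no change at the digits printed from compound 2 to compound 4 (within the scatter) despite being different groups. Hydroxy in place of carboxy gives a number 35 percentage points lower from compound 3 to compound 4 (beyond the scatter), so the carboxy-bearing compound 3 keeps its lead over compound 4. Nothing available explains these steps. Open, as far as these compounds go, is whether an amine or a methyl ester in place of the carboxy group would keep the number of compound 3. Also open, from the compounds shown here alone, is how 2-hydroxyphenyl would compare with 4-hydroxyphenyl.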